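Pyrrolidinyl for fluoro on the hydroxylated chalcone series

A few compounds are considered here, and "the series" means these few. Any claim that something is new, unique, unknown or untested is made for them only; others in the source may bear on it.

Three compounds of this series are shown: compound 1 `COc1cc(O)ccc1/C=C/C(=O)c1ccc(N)cc1` gives "not determined" (no result reported) in a functional assay on T47D cells (Homo sapiens) for cytotoxicity, read by MTT assay (on this read-out lower numbers stand for stronger inhibition and higher numbers for weaker inhibition), and compound 3 `COc1ccc(/C=C/C(=O)c2ccc(O)cc2)cc1Br` gives "not determined" (no result reported) in this assay, so no number is reported for either. Compound 2 `O=C(/C=C/c1ccc(F)cc1)c1ccc(O)cc1O` therefore stands alone with the only number shown, and in this assay compound 2 gives 8310 nM. For the measured compounds named here, no comparison between measured compounds is available, so nothing about the size of a structural step has yet been seen.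

Compound 4 `O=C(/C=C/c1ccc(N2CCCC2)cc1)c1ccc(O)cc1O` differs from compound 2 in one place: pyrrolidin-1-yl in place of fluoro on an aromatic carbon. Going by the values given here, with no measured step to lean on, the expectation rests on the single value of compound 2 in this assay and on the change itself; a moderate step toward stronger inhibition is expected, though a step within the usual scatter would not be surprising. The expected step from compound 2 to compound 4 in this assay is a 2.1-fold lower number from compound 2 to compound 4 (0.32 log units; beyond the scatter). Compound 4 is estimated in this assay at 4000 nM, with a range from 1200 nM to 13000 nM.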

Compound 4, half-maximal inhibitory concentration: 6990 nM
The estimate for compound 4 lay 1.7-fold (0.24 log units) below the measured number; low and high end bracket the measured number.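

In this assay the series now has its first measured step, a 1.2-fold lower number from compound 2 to compound 4 (0.08 log units; within the scatter) and so compound 2 and compound 4 cannot be told apart on this read-out. At this aromatic carbon, para to a large group, a single fluoro and the larger pyrrolidin-1-yl ring, with its five heavy atoms and one hydrogen-bond acceptor, give no separation beyond the scatter. No supporting measurement explains this result.

For the compounds shown here, compound 1 and compound 3 carry no number, so no step through them can be read. Still open, on these data alone, is whether a carboxylic acid, a morpholin-4-yl ring or a longer chain at this place would read differently in this assay and whether this single pair holds on other substitution patterns of the shared core.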